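Solubility notes on an aryloxyacetanilide series

The source may report more compounds than this note shows. Statements on the series, on what has been measured and on what is new or still open speak of the compounds shown alone.

Measured so far in a physicochemical assay for solubility, in phosphate buffer, measured as kinetic solubility, with a stated time of 1 h, at pH 7.4; on this read-out higher numbers stand for higher solubility and lower numbers for lower solubility:
compound 1 `Cc1cc(C)cc(NC(=O)COc2cc(C)nc3ccc(C)cc23)c1`, 83000 nM
compound 2 `COc1ccc2nc(C)cc(OC(C)C(=O)Nc3cc(C)cc(C)c3)c2c1`, 61000 nM
compound 3 `COc1ccc2nc(C)cc(OCC(=O)Nc3ccccc3)c2c1`, 63000 nM

The three numbers lie close together. Compound 3 sits among them: its gap to compound 2 and its gap to compound 1 are both within the usual scatter of this assay, so on these data the three compounds cannot be told apart, and compound 3 can be called neither the better nor the worse solubilised of the set. Within the data shown here, no pair of measured compounds differs in a single place, so no step size has been observed.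

The next compound, compound 4 `COc1ccc2nc(C)cc(OCC(=O)Nc3noc(C)c3C)c2c1`, differs from compound 3 in one place: 4,5-dimethyl-1,2-oxazol-3-yl in place of phenyl on an amide-type nitrogen. Among the measured compounds shown here, with no measured step of this kind to lean on, the expectation rests on the value of compound 3 alone. The step from compound 3 to compound 4 is expected to be small, most likely no larger than the scatter, with the direction left open; the estimate is a 1.2-fold higher number from compound 3 to compound 4 (0.08 log units; within the scatter). In this assay compound 4 is therefore expected to give about 75000 nM, with a range from 35000 nM to 160000 nM.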

Compound 4, solubility: 196000 nM
Beside the measured number, compound 4's estimate is 2.6-fold (0.42 log units) below it, and the stated range ends below it.
By their numbers in this assay, from the lowest: compounds 2, 3 and 1 (each within the scatter of the next); then compound 4.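

In this assay, among these compounds, the amide-type nitrogen is the first place where a single change gives a measurable step: 4,5-dimethyl-1,2-oxazol-3-yl in place of phenyl gives a 3.1-fold higher number from compound 3 to compound 4 (0.49 log units; beyond the scatter), which lies beyond the scatter. The change replaces a six-membered aromatic ring of carbon only with a five-membered aromatic ring with 2 hetero atoms, adds 2 hydrogen-bond acceptors and leaves both groups with no net charge, but one step cannot show which of these differences matters. No measurement here bears on the cause of the step.

The compounds shown do not separate the contribution of the ring hetero atoms from that of the two methyl groups, a question that an unsubstituted 1,2-oxazol-3-yl or a pyridyl group on the same nitrogen would address. From the compounds shown here alone, it also remains open whether the same replacement gives a step of similar size on the core of compound 1 or with the branched linker of compound 2.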